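A few compounds are considered here, and "the series" means these few. Any claim that something is new, unique, unknown or untested is made for them only; others in the source may bear on it.

For the measured compounds named here, in a physicochemical assay for solubility, at pH 6.8 (on this read-out higher numbers stand for higher solubility and lower numbers for lower solubility), compound 2 (`CN1CCc2nc(C(=O)NC3CCNCC3NC(=O)c3cc4cc(Cl)ccc4[nH]3)sc2C1`) gives 830 ug/mL as the only true number so far. Compound 1 (`CN1CCc2nc(C(=O)NC3CCN(C(=O)OC(C)(C)C)CC3NC(=O)c3cc4cc(Cl)ccc4[nH]3)sc2C1`) gives < 1 ug/mL in this assay and that reading is a limit of the assay, not a number. Compound 3 (`CC(=O)N1CCC(NC(=O)c2nc3c(s2)CN(C)CC3)C(NC(=O)c2cc3cc(Cl)ccc3[nH]2)C1`) differs from compound 2 by acetyl in place of hydrogen on an amine nitrogen in a ring. Going by the values given here, one measured step bears on this nitrogen: an at least 830-fold higher number from compound 1 to compound 2 (2.91 log units; beyond the scatter) is large and beyond the scatter, with hydrogen replacing tert-butoxycarbonyl there. Read in reverse, it suggests that putting a group back on the nitrogen should lower the number in this assay by a large step. A single step with a different group is a thin guide, however, and the fall need not reach the limit. For compound 3 the expected value is 40 ug/mL with an estimated range from 5 ug/mL to 250 ug/mL in this measurement. That estimate amounts to an expected 21-fold lower number from compound 2 to compound 3 (1.32 log units; beyond the scatter) in this assay once the measurement is made.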

Compound 3, solubility: 290 ug/mL
Compound 3: the middle estimate sits 7.3-fold (0.86 log units) below what was measured, and the stated range ends below it.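

In this assay, placing a group on this ring nitrogen does not by itself take the reading down to the limit, as acetyl in place of hydrogen gives a 2.9-fold lower number from compound 2 to compound 3 (0.46 log units; beyond the scatter). Methyl in place of tert-butoxy on the carbonyl carbon gives an at least 290-fold higher number from compound 1 to compound 3 (2.46 log units; beyond the scatter), so the reading depends on what the carbonyl carries, not only on whether this nitrogen bears a carbonyl group. The reading for compound 1 is a limit and not a number: the limit of < 1 ug/mL in this assay, at which 1 of the 3 values shown sits.

The compounds shown place only hydrogen, acetyl and tert-butoxycarbonyl on this nitrogen, so it remains open where a plain methyl, a longer chain on the carbonyl or a sulfonyl group would fall. On these data alone, it also remains open whether a group carrying a carboxylic acid or a second amine would read closer to compound 2 or to compound 1.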